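The source may hold more compounds than are shown below. What is called first, only, known or untested is meant among the compounds shown, and "the series" means these compounds.

In a functional assay on U-266 cells (Homo sapiens) for inhibition, read by MTT assay, with a stated time of 48 h, tested at 0.1 uM (on this read-out lower numbers stand for less inhibition and higher numbers for more inhibition at the one concentration tested (going by the name of the read-out)), compound 1 `Cc1noc(C)c1-c1ccc2c(c1)C(c1ccccc1)N(Cc1ncc(-c3ccccc3)o1)C(=O)N2C` gives 15.1%, compound 2 `Cc1nc(-c2ccccc2)sc1CN1C(=O)N(C)c2ccc(-c3c(C)noc3C)cc2C1c1ccccc1` gives 7.19% and compound 3 `Cc1noc(C)c1-c1ccc2c(c1)C(c1ccccc1)N(Cc1nnc(-c3ccccc3)s1)C(=O)N2C` gives 20.3%. Compound 3 has the largest of these three numbers, yet it cannot be set apart from compound 1, since a number 5.2 percentage points higher from compound 1 to compound 3 (within the scatter); only against compound 2 does it stand clear, as a number 13.1 percentage points higher from compound 2 to compound 3 (beyond the scatter). The third pairing, a number 7.9 percentage points lower from compound 1 to compound 2 (within the scatter), is likewise small.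

Compound 4 `Cc1noc(C)c1-c1ccc2c(c1)C(c1ccccc1)N(Cc1nc(-c3ccc(F)cc3)cs1)C(=O)N2C` differs from compound 3 in one place: 4-(4-fluorophenyl)-1,3-thiazol-2-yl in place of 5-phenyl-1,3,4-thiadiazol-2-yl on a saturated chain carbon bound to an amide-type nitrogen in a ring. All three measured steps concern exactly this spot, the five-membered heteroaryl on the saturated chain carbon bound to the amide-type nitrogen in the ring, and two of them stayed within the scatter while the third was only modest. The entering group shares its thiazole ring type with the group in compound 2, which gave the smallest number, although it is joined at a different ring position and carries a fluorine on the phenyl. On this basis compound 4 is expected to show at most a small downward step, a number 6.3 percentage points lower from compound 3 to compound 4 (within the scatter), not clearly beyond the scatter. In this assay compound 4 is therefore estimated at 14%, with a likely range from 3% to 25%.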

Compound 4, a percentage reported as inhibition, at one concentration (the size of the read-out at that concentration, not a potency): 12.6%
Compound 4: the middle estimate sits 1.4 percentage points above what was measured; measured number inside the range.
By their numbers in this assay, from the lowest: compounds 2, 4, 1 and 3 (each within the scatter of the next, the first and the last beyond it).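

In this assay, the 4-(4-fluorophenyl)-1,3-thiazol-2-yl group on a saturated chain carbon bound to an amide-type nitrogen in a ring cannot be told apart from any of the three groups seen there before, with a number 7.7 percentage points lower from compound 3 to compound 4 (within the scatter), a number 5.4 percentage points higher from compound 2 to compound 4 (within the scatter) and a number 2.5 percentage points lower from compound 1 to compound 4 (within the scatter). Within the data shown here, the one clear gap at this position, a number 13.1 percentage points higher from compound 2 to compound 3 (beyond the scatter), now has compound 4 lying within the scatter of both its ends, even though the entering group brings a fluorine and a thiazole joined differently from the one in compound 2. Nothing available explains these steps or says what the change does at this position.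

All four groups shown here are five-membered aromatic rings carrying a phenyl or fluorophenyl, which leaves open what an amine, a carboxylic acid or a longer chain would give on the same saturated chain carbon. On these data alone, with readings at a single concentration, it also remains open whether the compounds that cannot be separated here would stay together at other concentrations.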